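A few compounds are considered here, and "the series" means these few. Any claim that something is new, unique, unknown or untested is made for them only; others in the source may bear on it.

In a physicochemical assay for solubility, at pH 7.4 (on this read-out higher numbers stand for higher solubility and lower numbers for lower solubility), the measured compounds read as follows.

Compound 1 `CN(C)c1nc(NCc2ccc(NC(=O)c3ccc(F)cc3)cc2)c2ccc(I)cc2n1` gives > 100 ug/mL as a limit of the assay, not a number
Compound 2 `CN(C)c1nc(NCc2ccc(NC(=O)c3ccc(F)cc3)cc2)c2ccc(C=O)cc2n1` gives 1 ug/mL on the same read-out
Compound 3 `CN(C)c1nc(NCc2ccc(NC(=O)c3ccc(F)cc3)cc2)c2ccc(CO)cc2n1` gives 4 ug/mL on the same read-out

Only two of these are true numbers, and the higher belongs to compound 3. Its gap to the nearest number is modest, a 4.0-fold higher number from compound 2 to compound 3 (0.60 log units; beyond the scatter), while the gap to the limit is large, an at least 25-fold lower number from compound 1 to compound 3 (1.39 log units; beyond the scatter), and the other large step is an at least 100-fold lower number from compound 1 to compound 2 (2.00 log units; beyond the scatter) here.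

The next compound, compound 4 `CN(C)Cc1ccc2c(NCc3ccc(NC(=O)c4ccc(F)cc4)cc3)nc(N(C)C)nc2c1`, keeps the shared core and carries one change, (dimethylamino in place of hydroxy on a saturated chain carbon bound to an aromatic carbon), which is dimethylamino in place of hydroxy on a saturated chain carbon bound to an aromatic carbon. Among the measured compounds shown here, no measured step brings in dimethylamino. The nearest guide is the modest step ending in the hydroxymethyl group, a 4.0-fold higher number from compound 2 to compound 3 (0.60 log units; beyond the scatter), with hydroxymethyl in place of formyl. Both large steps start from compound 1 and rest on (the limit of > 100 ug/mL in this assay, at which 1 of the 3 values shown sits), so they give no exact size. Starting from compound 3 at 4 ug/mL and taking that modest step as a measure, a modest upward move is expected in this assay, though the direction is uncertain. The expected move is a 3.0-fold higher number from compound 3 to compound 4 (0.48 log units; beyond the scatter) in this estimate. For compound 4 the estimated value is 12 ug/mL, within an expected range from 3 ug/mL to 60 ug/mL for this read-out.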

Compound 4, solubility: 55 ug/mL
The estimate for compound 4 lay 4.6-fold (0.66 log units) below the measured number; measured number inside the range.
By their numbers in this assay, from the lowest: compound 2; then compound 3; then compound 4. At a limit, above all of these: compound 1.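

In this assay dimethylamino in place of hydroxy on a saturated chain carbon bound to an aromatic carbon gives (a 14-fold higher number from compound 3 to compound 4 (1.14 log units; beyond the scatter)), a larger step than the only earlier one between two true numbers (a 4.0-fold higher number from compound 2 to compound 3 (0.60 log units; beyond the scatter)). Set against formyl, (dimethylamino)methyl on the same aromatic carbon gives (a 55-fold higher number from compound 2 to compound 4 (1.74 log units; beyond the scatter)), so the three groups with true numbers at this place now rise in the order formyl, hydroxymethyl, (dimethylamino)methyl, and this place is shown to carry a far wider span of numbers than the two earlier true numbers showed. Against iodo, (dimethylamino)methyl on the same aromatic carbon gives (an at least 1.8-fold lower number from compound 1 to compound 4 (0.25 log units; that floor lies within the scatter)), a step with no exact size. Compound 1 stands at a limit and not at a number: the limit of > 100 ug/mL in this assay, at which 1 of the 4 values shown sits.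

The compounds shown leave open whether the step belongs to the nitrogen of the dimethylamino group or to its two added carbons, since both enter together. They also leave open how in this assay a primary amine, a carboxylic acid or a longer chain between the amine and the aromatic carbon would read at this place.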